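A few compounds are considered here, and "the series" means these few. Any claim that something is new, unique, unknown or untested is made for them only; others in the source may bear on it.

Measured compounds in an assay on isolated protein for inhibition of CAAX prenyl protease 2 (Homo sapiens), with stated times of 60 s and 60 min; a higher number here means a weaker inhibitor, a lower number a stronger inhibitor:

Compound 1 `Oc1c(C(Nc2ccccc2)c2ccccc2)ccc2cccnc12`: 8900 nM
Compound 2 `Cc1ccc(C(Nc2ccc(C(=O)O)cc2)c2ccc3cccnc3c2O)cc1`: 7100 nM
Compound 3 `O=C(O)c1ccc(NC(c2ccc(Br)cc2)c2ccc3cccnc3c2O)cc1`: 6700 nM

Among these three, compound 1 carries the highest number, but neither of the other two is separated from it by more than the usual scatter: compound 2 sits close to it, and compound 3 sits only slightly further away. Going by the values given here, the one step within the measured set that changes a single place, a 1.1-fold lower number from compound 2 to compound 3 (0.03 log units; within the scatter), stays within the scatter as well, so the measured compounds give no example of a single substitution that shifted this assay to a notable degree.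

Compound 4 `Cc1ccc(NC(c2ccccc2)c2ccc3cccnc3c2O)cc1` has not yet been measured. It differs from compound 1 by methyl in place of hydrogen on an aromatic carbon, on the aromatic ring of the anilino group, para to a large group. Among the compounds with values here, no measured step concerns this very position; the only step available, from a methyl to a bromo on the other aryl ring, was flat. On that basis a step beyond the scatter is not expected in this assay, and the estimated step is a 1.1-fold lower number from compound 1 to compound 4 (0.05 log units; within the scatter). Compound 4 is therefore expected to give about 8000 nM, with a likely range from 3500 nM to 18000 nM.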

Compound 4, half-maximal inhibitory concentration: 8800 nM
For compound 4 the middle estimate is 1.1-fold (0.04 log units) below the measured one, within the range that was stated.
By their numbers in this assay, from the lowest: compounds 3, 2, 4 and 1 (each within the scatter of the next).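

In this assay, the anilino ring now has a measured single-place step of its own: methyl in place of hydrogen on an aromatic carbon, para to a large group, gives a 1.0-fold lower number from compound 1 to compound 4 (0.00 log units; within the scatter). Going by these compounds alone, the only earlier step of this kind, bromo for methyl on the other aryl ring, gave a 1.1-fold lower number from compound 2 to compound 3 (0.03 log units; within the scatter), so a change on either aryl ring has now been seen without a step beyond the scatter, though each ring is represented by one change only. No measurement shown here accounts for this result.

Going by these compounds, whether a different group at this same place, such as an amine, a methoxy group or a longer chain like butyl, would give a step beyond the scatter remains open, as one methyl says little about the range of groups this place tolerates. On these data alone, it is also open whether methyl in place of hydrogen would give the same result in compounds carrying a carboxylic acid, such as compound 2 and compound 3.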